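The compounds below may be only part of what the source reports. "The series", "measured", "known", "first", "only" and "open" are said of these compounds alone.

Four compounds built on a shared core are examined here. Compound 1 `COc1cc2c(Nc3cccc(C#N)c3)ncnc2cc1OCCCN1CCCC1` is the reference point. Compound 2 `COc1cc2c(Nc3cccc(C#N)c3)ncnc2cc1OCCCN1CCCCC1` differs from it by one change, (piperidin-1-yl in place of pyrrolidin-1-yl on a saturated chain carbon, three bonds along the chain from an oxygen on an aromatic ring). Compound 3 `COc1cc2c(Nc3ccccc3C#N)ncnc2cc1OCCCN1CCCC1` carries a different change at a different place, (2-cyanophenyl in place of 3-cyanophenyl on a nitrogen on an aromatic ring), and this is how the core of compound 3 differs from the core of compound 1. Compound 4 `COc1cc2c(Nc3ccccc3C#N)ncnc2cc1OCCCN1CCCCC1` combines both changes and has not yet been measured.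

In a functional assay on HepG2 cells (Homo sapiens) for antiproliferative activity, read by MTT assay, with a stated time of 72 h (a lower number here means a stronger inhibitor, a higher number a weaker inhibitor), compound 1 gives 18200 nM. Compound 2 gives 29500 nM, and the step of a 1.6-fold higher number from compound 1 to compound 2 (0.21 log units; within the scatter). Compound 3 gives 24500 nM, with a step of a 1.3-fold higher number from compound 1 to compound 3 (0.13 log units; within the scatter). Compounds 2 and 3 are not compared directly by a step; their two values simply lie close to one another.

The change from compound 3 to compound 4 is piperidin-1-yl in place of pyrrolidin-1-yl on a saturated chain carbon, three bonds along the chain from an oxygen on an aromatic ring. Within the data shown here, this is the same change as the one from compound 1 to compound 2, made at the same place on a different core. That earlier step was a 1.6-fold higher number from compound 1 to compound 2 (0.21 log units; within the scatter). On that basis the step expected from compound 3 to compound 4 in this assay is a 1.6-fold higher number from compound 3 to compound 4 (0.20 log units; within the scatter), resting on the value of compound 3, 24500 nM, and on the size of the earlier step. Compound 4 is therefore estimated at 39000 nM, expected to fall between 18000 nM and 85000 nM.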

Compound 4, half-maximal inhibitory concentration: 14200 nM
For compound 4 the middle estimate is 2.7-fold (0.44 log units) above the measured one, and the stated range ends above it.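

Carried to the core of compound 3, the exchange of pyrrolidin-1-yl for piperidin-1-yl in this assay gives a 1.7-fold lower number from compound 3 to compound 4 (0.24 log units; within the scatter), and this step does not match its counterpart on the core of compound 1: the same change on two cores in this assay, a 1.6-fold higher number (0.21 log units; within the scatter) from compound 1 to compound 2 and a 1.7-fold lower number (0.24 log units; within the scatter) from compound 3 to compound 4, 2.8-fold (0.45 log units) apart, beyond the scatter of two such steps

The exchange of 3-cyanophenyl for 2-cyanophenyl, read with piperidin-1-yl on the chain, gives a 2.1-fold lower number from compound 2 to compound 4 (0.32 log units; beyond the scatter), a modest step that likewise does not match its counterpart with pyrrolidin-1-yl: the same change on two cores in this assay, a 1.3-fold higher number (0.13 log units; within the scatter) from compound 1 to compound 3 and a 2.1-fold lower number (0.32 log units; beyond the scatter) from compound 2 to compound 4, 2.8-fold (0.45 log units) apart, beyond the scatter of two such steps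

This shows that neither change can be carried from one core to the other as a fixed step in these compounds, but the two gaps come from the same four values and so count as a single observation of the two changes failing to add up, and they do not show why that happens or whether it would recur elsewhere in the series.

The compounds shown leave open whether the same mismatch would appear with other amines at the end of the chain, such as morpholine or dimethylamine, or with a shorter or longer chain than 3-(piperidin-1-yl)propyl. They also leave open what would happen if the nitrile on the phenyl ring gave way to a chlorine or a methoxy group.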